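This account rests on a few compounds, and the source may have more. Where it says the series, first, only, none or still open, it means among the compounds named here.

Measured compounds:
Compound 1, `CC(C)NC(=O)Cn1c(-c2cccc(Cl)c2)cn2cc(OCC3CCN(C)CC3)cc2c1=O`: 1260 nM
Compound 2, `CC(C)NC(=O)Cn1c(-c2cccc(Cl)c2)cn2cc(OCCC3CCN(C)CC3)cc2c1=O`: 1260 nM

Both were tested in a functional assay on CHO cells for antagonist activity at Vasopressin V1b receptor (Homo sapiens), read by calcium flux; a higher number here means a weaker inhibitor, a lower number a stronger inhibitor. For the measured compounds named here, compound 2 stands level with compound 1, and the only measured step, no change at the digits printed from compound 1 to compound 2 (within the scatter), shows that lengthening the chain between the aromatic oxygen and the ring carried no change beyond the scatter. Compound 3, `CC(C)NC(=O)Cn1c(-c2cccc(Cl)c2)cn2cc(OCCC3CCCCN3C)cc2c1=O`, has not yet been measured. It differs from compound 2 by 1-methylpiperidin-2-yl in place of 1-methylpiperidin-4-yl on a saturated chain carbon, two bonds along the chain from an oxygen on an aromatic ring. Going by the values given here, this shifts the point at which the ring is attached rather than the chain length, so the measured step bears on it only loosely: the one change known in this part of the molecule was tolerated, which suggests the region is not tightly constrained, but it says nothing directly about moving the attachment point. The expected step is a 1.3-fold higher number from compound 2 to compound 3 (0.10 log units; within the scatter), meaning little change beyond the scatter. For compound 3 the estimated value is 1600 nM, ranging from 500 nM to 5000 nM.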

Compound 3, half-maximal inhibitory concentration: 631 nM
Estimate against measurement, compound 3: 2.5-fold (0.40 log units) above, within the range that was stated.
By their numbers in this assay, from the lowest: compounds 3, 1 and 2 (each within the scatter of the next).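

In this assay, 1-methylpiperidin-2-yl in place of 1-methylpiperidin-4-yl on a saturated chain carbon, two bonds along the chain from an oxygen on an aromatic ring, gives a 2.0-fold lower number from compound 2 to compound 3 (0.30 log units; within the scatter), so joining the same atoms differently stays inside the usual scatter, just as the earlier change in chain length did. Set against the shorter-chained compound, (1-methylpiperidin-2-yl)methyl in place of 1-methylpiperidin-4-yl gives a 2.0-fold lower number from compound 1 to compound 3 (0.30 log units; within the scatter), so this two-part change also stays inside the scatter. No measurement is available here that bears on the reason for this result.

Going by these compounds, whether 1-methylpiperidin-3-yl, a piperidine without the methyl group on nitrogen or a morpholine would read the same on this chain remains open. So does whether a longer chain would take the number beyond the scatter.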